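Swapping a Carboxypyridine for a Methyl Ester

The source may report more compounds than this note shows. Statements on the series, on what has been measured and on what is new or still open speak of the compounds shown alone.

Of the compounds shown here, three have been measured in an assay for inhibition of Fatty-acid amide hydrolase 1 (Rattus norvegicus); on this read-out lower numbers stand for stronger inhibition and higher numbers for weaker inhibition. Compound 1 `O=C(O)c1ccc(-c2cnc(C(=O)CCc3ccc(-c4ccccc4)cc3)o2)cn1` gives 44 nM, the second highest of the three numbers. Compound 3 `O=C(CCc1ccc(COc2ccccc2)cc1)c1ncco1` gives 25 nM, which sits within the usual scatter of the number for compound 1, so the two cannot be told apart. Compound 2 `O=C(O)c1cccc(-c2cnc(C(O)CCc3ccc(-c4ccccc4)cc3)o2)n1` gives 1100 nM, the highest number of the set and well beyond the scatter from compound 1.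

Compound 4 `COC(=O)c1cnc(C(=O)CCc2ccc(-c3ccccc3)cc2)o1` has not yet been measured in this assay. It differs from compound 1 in one place: methoxycarbonyl in place of 6-carboxypyridin-3-yl on an aromatic carbon. The group that enters sits on an aromatic carbon of a five-membered aromatic ring with 1 nitrogen and 1 oxygen, in the same position that the leaving group held.

Because compound 3 gives 25 nM with no substituent at all in that position, the shared core appears to carry the inhibition largely on its own. The step of a 1.1-fold lower number from compound 1 to compound 4 (0.04 log units; within the scatter) is therefore expected to be small, with no direction beyond the scatter. Compound 4 is estimated at 40 nM, within a range from 10 nM to 160 nM.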

Compound 4, inhibition constant: 1.5 nM
For compound 4 the middle estimate is 27-fold (1.43 log units) above the measured one; the whole stated range lies above it.
By their numbers in this assay, from the lowest: compound 4; then compounds 3 and 1 (each within the scatter of the next); then compound 2.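

In this assay, for the compounds shown here, putting methoxycarbonyl in place of 6-carboxypyridin-3-yl gives a 29-fold lower number from compound 1 to compound 4 (1.47 log units; beyond the scatter) and this is the first step in the set that changes only one place. It shows that the group on this aromatic carbon, next to the ring oxygen, can move the number a long way, and that a group of 4 heavy atoms with no ring can stand on the stronger side of one with 9 heavy atoms and a ring. Nothing available bears on why this step is so large.

The change removes a ring and a carboxylic acid and brings in an ester all at once, so the compounds shown cannot say which of these matters. A nitrile, a primary amide or an ethyl ester in the same position would help separate them.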